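This account rests on a few compounds, and the source may have more. Where it says the series, first, only, none or still open, it means among the compounds named here.

Measured so far in a functional assay on U-251 cells (Homo sapiens) for inhibition, read by MTT assay, with a stated time of 72 h; a higher number here means a weaker inhibitor of growth, a lower number a stronger inhibitor of growth:

- compound 1 `O=C1CC(N2C(=O)/C(=C/C(Cl)=C/c3ccc([N+](=O)[O-])cc3)SC2=S)C(=O)N1c1ccc(Cl)cc1`: 8930 nM
- compound 2 `C=CCOc1ccccc1/C=C1\SC(=S)N(C2CC(=O)N(c3ccc(Cl)cc3)C2=O)C1=O`: 91200 nM

Compound 2, at 91200 nM, has the higher of the two numbers and is the weaker inhibitor of growth, with a gap to compound 1 that lies beyond the scatter. Compound 3 `C=CCOc1cccc(/C=C2\SC(=S)N(C3CC(=O)N(c4ccc(Cl)cc4)C3=O)C2=O)c1` is not yet measured. It differs from compound 2 by 3-(allyloxy)phenyl in place of 2-(allyloxy)phenyl on a double-bonded chain carbon bound to a double-bonded ring carbon, with the same atoms joined differently. Among the compounds with values here, no measured pair shows this kind of change, so only a small step towards a lower number, about the size of the scatter, is expected in this assay. The expected change is a 1.8-fold lower number from compound 2 to compound 3 (0.26 log units; within the scatter), and this remains uncertain. For compound 3 the estimate is 50000 nM, with an expected range from 12000 nM to 120000 nM in this assay.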

Compound 3, concentration for 50% growth inhibition: > 100000 nM
Compound 3 gave a limit, no number (the forecaster's own chance of this, stated with the estimate: 15%); at least 2.0-fold (0.30 log units) between middle value and limit.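

In this assay compound 3 gives > 100000 nM, which is a limit of the assay and not a number. Putting 3-(allyloxy)phenyl in place of 2-(allyloxy)phenyl gives an at least 1.0-fold higher number from compound 2 to compound 3 (0.04 log units; that floor lies within the scatter), so this change on a double-bonded chain carbon bound to a double-bonded ring carbon shows no sign of a lower number. The full size of the step cannot be read because the value is a limit: the limit of > 100000 nM in this assay, at which 1 of the 3 values shown sits.

The compounds shown leave open whether a smaller ether such as methoxy, or a carboxylic acid, at this place on the phenyl ring would give a lower number.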